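This account rests on a few compounds, and the source may have more. Where it says the series, first, only, none or still open, it means among the compounds named here.

Compound 1 `Cc1cccc(-c2nc(CNc3ccc(C(=O)NO)cc3)n(-c3ccccc3)n2)c1`: 64.1%
Compound 2 `O=C(NO)c1ccc(NCc2nc(-c3ccccn3)nn2-c2ccccc2)cc1`: 58.6%
Compound 3 `O=C(NO)c1ccc(NCc2nc(-c3ccsc3)nn2-c2ccccc2)cc1`: 53.4%

All three share one core and differ only in the group on an aromatic carbon. In an assay on Sf9 cells for inhibition of protein deacetylase HDAC6 (Homo sapiens), read by fluorescence, with a stated time of 40 min, tested at 100 nM (on this read-out lower numbers stand for less inhibition and higher numbers for more inhibition at the one concentration tested (going by the name of the read-out)), compound 3 holds the lowest of the three numbers: compound 2 sits within the scatter of it, while compound 1 lies beyond it, as a number 10.7 percentage points lower from compound 1 to compound 3 (beyond the scatter) and a number 5.2 percentage points lower from compound 2 to compound 3 (within the scatter) show. Compound 4 `O=C(NO)c1ccc(NCc2nc(-c3cccc4cnccc34)nn2-c2ccccc2)cc1` changes the same place: isoquinolin-5-yl in place of thiophen-3-yl on an aromatic carbon. Both measured steps that bear on this swapped an aromatic group for thiophen-3-yl, one of them beyond the scatter, so moving away from thiophen-3-yl to isoquinolin-5-yl is expected to bring a modest rise. Compound 4 is estimated at 60%, with a range from 45% to 75%, which means an expected step of a number 6.6 percentage points higher from compound 3 to compound 4 (within the scatter).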

Compound 4, a percentage reported as inhibition, at one concentration (the size of the read-out at that concentration, not a potency): 40.2%
Estimate against measurement, compound 4: 19.8 percentage points above, outside the stated range (below it).
By their numbers in this assay, from the lowest: compound 4; then compounds 3, 2 and 1 (each within the scatter of the next, the first and the last beyond it).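

Isoquinolin-5-yl, with two aromatic rings where every earlier group has one, is the first group here to stand clearly apart at this position in this assay: it gives a number 13.2 percentage points lower from compound 3 to compound 4 (beyond the scatter), a number 18.4 percentage points lower from compound 2 to compound 4 (beyond the scatter) and a number 23.9 percentage points lower from compound 1 to compound 4 (beyond the scatter). So this position does not accept every aromatic group alike, and compound 4 is the lowest of the four. No measurement here explains this drop. On these data alone, it remains open whether the second ring or its ring nitrogen goes with the lower number, and how a naphthalen-1-yl group, with carbon only in both rings, or a small amine would read here.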